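A few compounds are considered here, and "the series" means these few. Any claim that something is new, unique, unknown or untested is made for them only; others in the source may bear on it.

Of the compounds shown here, three sharing one core have been tested in a functional assay on the whole organism with Mus musculus as the target, with a stated time of 1 h, at a dose of 100 mg/kg by the intraperitoneal route; on this read-out higher numbers stand for more inhibition at the one dose given (going by the name of the read-out) and lower numbers for less inhibition. Compound 1 `c1ccc(COc2nc3ccccc3s2)cc1` gives 68.8%. Compound 2 `FC(F)(F)c1ccc(COc2nc3ccccc3s2)cc1` gives 12.2%, and compound 3 `O=[N+]([O-])c1ccc(COc2nc3ccccc3s2)cc1` gives 4.39%, the lowest of the three numbers, though its gap to compound 2 lies within the scatter. The steps of a number 56.6 percentage points lower from compound 1 to compound 2 (beyond the scatter) and a number 64.4 percentage points lower from compound 1 to compound 3 (beyond the scatter) were large, while a number 7.8 percentage points lower from compound 2 to compound 3 (within the scatter) was small. Compound 4 `Fc1ccc(COc2nc3ccccc3s2)cc1` differs from compound 3 by fluoro in place of nitro on an aromatic carbon. Going by the values given here, no measured step swaps one such group for fluoro, so the size of this step is uncertain; because a number 64.4 percentage points lower from compound 1 to compound 3 (beyond the scatter) was large, compound 4 is expected to land somewhere between the unsubstituted compound 1 and compound 3. The estimate for compound 4 is 40%, with a range from 10% to 70%, expected as a number 35.6 percentage points higher from compound 3 to compound 4 (beyond the scatter).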

Compound 4, a percentage reported as inhibition, in the whole organism at one dose (the size of the read-out at that dose, not a potency): 90.7%
Beside the measured number, compound 4's estimate is 50.7 percentage points below it; the whole stated range lies below it.
By their numbers in this assay, from the lowest: compounds 3 and 2 (each within the scatter of the next); then compound 1; then compound 4.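

Going by these compounds alone, at this place on the ring, this assay can move in both directions: fluoro is the first group to sit above the unsubstituted compound, with a number 21.9 percentage points higher from compound 1 to compound 4 (beyond the scatter), while trifluoromethyl and nitro both sit below it. The contrast among the substituents is far larger, with a number 78.5 percentage points higher from compound 2 to compound 4 (beyond the scatter) and a number 86.3 percentage points higher from compound 3 to compound 4 (beyond the scatter), so a group at this place is not harmful as such. Nothing available explains why these groups differ.

From the compounds shown here alone, whether chloro, methoxy or an amine here would behave like fluoro or like nitro remains open. So does whether fluoro elsewhere on this ring would do the same.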